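From 2-ethylphenyl to 3-chlorophenyl at the limit

The source may report more compounds than this note shows. Statements on the series, on what has been measured and on what is new or still open speak of the compounds shown alone.

In a functional assay on M21 cells (Homo sapiens) for antiproliferative activity, read by sulforhodamine B assay, with a stated time of 48 h (a higher number here means a weaker inhibitor, a lower number a stronger inhibitor), compound 1 `CCc1ccccc1OS(=O)(=O)c1ccc(N2CCN(C)C2=O)cc1` gives 2300 nM as a measured value, and compound 2 `CN1CCN(c2ccc(S(=O)(=O)Oc3cccc(F)c3)cc2)C1=O` gives 5800 nM as a measured value. Compound 3 `CCCN1CCN(c2ccc(S(=O)(=O)Oc3ccccc3CC)cc2)C1=O` reads > 50000 nM in this assay and this is a limit, not a number. Compound 3 sits at the limit of > 50000 nM in this assay, at which 1 of the 3 values shown sits, and so has no exact position in the series.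

Compound 4 `CCCN1CCN(c2ccc(S(=O)(=O)Oc3cccc(Cl)c3)cc2)C1=O` carries 3-chlorophenyl in place of 2-ethylphenyl on an oxygen, and the count for that change is 3-chlorophenyl in place of 2-ethylphenyl on an oxygen with the rest of compound 3 kept.

Among the measured compounds shown here, two measured steps bear on this. The closest exchange is a 2.5-fold higher number from compound 1 to compound 2 (0.40 log units; beyond the scatter) and it stays modest. The chain change kept in compound 4 is an at least 21-fold higher number from compound 1 to compound 3 (1.33 log units; beyond the scatter) and it is large. A step of modest size in the higher direction is therefore expected from the exchange, with no recovery from the large loss. For compound 4 the estimate is 45000 nM with an expected range of 15000 nM to 120000 nM in this assay as read. The expected step is an at least 1.1-fold lower number from compound 3 to compound 4 (0.04 log units; that floor lies within the scatter) and a further limit reading is likely.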

Compound 4, half-maximal inhibitory concentration: 8600 nM
Estimate against measurement, compound 4: 5.2-fold (0.72 log units) above, and the stated range ends above it.
By their numbers in this assay, from the lowest: compound 1; then compounds 2 and 4 (each within the scatter of the next). At a limit, above all of these: compound 3.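

On the chain of compound 3, the exchange at this oxygen gives an at least 5.8-fold lower number from compound 3 to compound 4 (0.76 log units; beyond the scatter), so the large loss that came with the chain change is not fixed and can be recovered, at least in part, by the group on the oxygen alone. Compound 3 reads as a limit and not a number, so the size of this step is only a floor: the limit of > 50000 nM in this assay, at which 1 of the 4 values shown sits. In this assay, the nearest exchange on the chain of compound 1, with 3-fluorophenyl as the incoming group, ran the other way, giving a 2.5-fold higher number from compound 1 to compound 2 (0.40 log units; beyond the scatter), so the two exchanges, which differ in their halogen as well as their chain, share no direction.

Open, from the compounds shown here alone, is how 3-chlorophenyl itself behaves on the chain of compound 1, and so whether the direction of the exchange depends on the chain or on the halogen. Also open, going by these compounds, is how a group such as an amine or a carboxylic acid on the same phenyl ring would read on either chain.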